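Compound 1 to Compound 3: a Swap on the Carbonyl Carbon

This account rests on a few compounds, and the source may have more. Where it says the series, first, only, none or still open, it means among the compounds named here.

Compound 1 `COc1cc(Nc2ncnc3c(NC(=O)Nc4ccc5c(c4)OCCO5)cccc23)cc(OC)c1`: 2750 nM
Compound 2 `COc1cc(Nc2ncnc3c(NC(=O)c4cccc(N5CCN(C)CC5)c4)cccc23)cc(OC)c1`: > 20000 nM

Going by the values given here, in a functional assay on RT-112 cells (Homo sapiens) for antiproliferative activity, read by MTT assay, with a stated time of 72 h (a lower number here means a stronger inhibitor of growth, a higher number a weaker inhibitor of growth), compound 1 gives 2750 nM, the only number here. Compound 2 gives > 20000 nM, which is a limit and not a number. Compound 3 `COc1cc(Nc2ncnc3c(NC(=O)c4cc(=O)c5ccccc5o4)cccc23)cc(OC)c1` is not yet measured; it differs from compound 1 by a group of 11 heavy atoms (9 carbon, 2 oxygen; one six-membered aromatic ring of carbon only, one six-membered aromatic ring with 1 hetero atom) in place of a group of 11 heavy atoms (8 carbon, 1 nitrogen, 2 oxygen; one six-membered non-aromatic ring with 2 hetero atoms, one six-membered aromatic ring of carbon only), on a carbonyl carbon. Among the compounds with values here, no step between measured compounds exists, so the size of this change is open. Compound 2 sits at the limit of > 20000 nM in this assay, at which 1 of the 2 values shown sits, and that weighs on the expectation. The step of a 2.9-fold higher number from compound 1 to compound 3 (0.46 log units; beyond the scatter) is expected to be a loss beyond the scatter. Compound 3 is expected near 8000 nM, between 2000 nM and 30000 nM.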

Compound 3, concentration for 50% growth inhibition: > 20000 nM
Compound 3 ended at the assay's limit (the forecaster's own chance of this, stated with the estimate: 35%); at least 2.5-fold (0.39 log units) between middle value and limit.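

In this assay, this change on a carbonyl carbon gives an at least 7.2-fold higher number from compound 1 to compound 3 (0.86 log units; beyond the scatter) and so costs growth inhibition beyond the scatter. Compound 3 gives a limit and not a number, so the step has a lower bound but no measured size. The entering group has no hydrogen-bond donor, while (2,3-dihydro-1,4-benzodioxin-6-yl)amino has one, and readings now gather at the limit: the limit of > 20000 nM in this assay, at which 2 of the 3 values shown sit.

This single change cannot show which difference between the two groups matters. On these data alone, whether a morpholine or a simple phenylamino group on this carbonyl carbon would hold the reading of compound 1 stays open.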